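Replacing pyridin-3-yl with 4-fluorophenyl on a shared oxadiazole-free core

A few compounds are considered here, and "the series" means these few. Any claim that something is new, unique, unknown or untested is made for them only; others in the source may bear on it.

The series is tested in a functional assay on PC-3 cells (Homo sapiens) for antiproliferative activity, read by MTT assay, with a stated time of 24 h; a lower number here means a stronger inhibitor, a higher number a weaker inhibitor. Compound 1 `c1ccc(-c2noc(-c3ccncc3)n2)cc1` gives only a limit of the assay there, > 1000000 nM. Compound 2 `COc1ccc(-c2noc(-c3ccc(F)cc3)n2)cc1O` likewise gives only a limit in this assay, > 1000000 nM. Compound 3 `COc1ccc(-c2noc(-c3cccnc3)n2)cc1OC1CCCC1` also gives only a limit in this assay, > 1000000 nM. No compound shown has a measured number, so compound 3 stands at the same limit as the other two; this is summed up in the limit of > 1000000 nM in this assay, at which 3 of the 3 values shown sit.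

Compound 4 `COc1ccc(-c2noc(-c3ccc(F)cc3)n2)cc1OC1CCCC1` has not yet been measured in this assay. It differs from compound 3 in one place: 4-fluorophenyl in place of pyridin-3-yl on an aromatic carbon.

Among the compounds with values here, no measured step between compounds exists here, so the size of the change cannot be read from the data. Compound 2 already carries 4-fluorophenyl and gives only a limit, > 1000000 nM, which suggests that the step from compound 3 to compound 4 is expected to stay within the scatter, most likely ending again at a limit. Compound 4 is therefore estimated at 2000000 nM, with a range from 300000 nM to 10000000 nM, and the expected change is a step that the limit leaves unreadable from compound 3 to compound 4.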

Compound 4, half-maximal inhibitory concentration: > 1000000 nM
Compound 4 was reported as a limit; the forecaster's own chance of this, stated with the estimate: 85%; the middle value is on the limit's open side.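

Compound 4 also gives only a limit, so no step to it from compound 3 or from compound 2 can be read; every value shown stands at one limit: the limit of > 1000000 nM in this assay, at which 4 of the 4 values shown sit.

The compounds shown leave open which change on the shared core, if any, would give a measured number in this assay.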